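The compounds below may be only part of what the source reports. "The series", "measured", "known", "first", "only" and "open" are said of these compounds alone.

In an ADME assay on cells (Homo sapiens) for cytotoxicity, read by resazurin assay, with a stated time of 5 days (on this read-out lower numbers stand for higher toxicity in this test and higher numbers for lower toxicity in this test), compound 1 (`COc1ccc(-c2nc(CC(O)c3cccc(Cl)c3)nc3ccsc23)cn1`) gives 31000 nM. Compound 2 (`COc1ccc(-c2nc(CSc3cc(C)cc(C)c3)nc3ccsc23)cn1`) gives > 50000 nM, which is a limit of the assay and not a number. Compound 3 (`COc1ccc(-c2nc(CSc3cc(Cl)ccc3Cl)nc3ccsc23)cn1`) differs from compound 2 in one place: 2,5-dichlorophenyl in place of 3,5-dimethylphenyl on a sulfur. In words, 2,5-dichlorophenyl stands in place of 3,5-dimethylphenyl on a sulfur. Among the compounds with values here, the only measured step that bears on this is an at least 1.6-fold higher number from compound 1 to compound 2 (0.20 log units; that floor lies within the scatter), so no change beyond the scatter is expected in this assay. The expected step is an at least 1.2-fold lower number from compound 2 to compound 3 (0.09 log units; that floor lies within the scatter). For compound 3 the estimated value is 40000 nM, within an expected range of 18000 nM to 70000 nM.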

Compound 3, half-maximal cytotoxic concentration: > 50000 nM
Compound 3: only a limit was reported; the forecaster's own chance of this, stated with the estimate: 50%; middle value at least 1.2-fold (0.09 log units) from the limit.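

In this assay compound 3 gives > 50000 nM, which is a limit of the assay and not a number. Within the data shown here, the step between compound 2 and compound 3 cannot be read, so swapping 3,5-dimethylphenyl for 2,5-dichlorophenyl on the sulfur cannot be sized, while the one readable step is an at least 1.6-fold higher number from compound 1 to compound 3 (0.20 log units; that floor lies within the scatter). A second group on the sulfur now reaches the same ceiling: the limit of > 50000 nM in this assay, at which 2 of the 3 values shown sit.

Going by these compounds, what stays open is whether any group on this sulfur gives a real number under that limit. A phenyl ring carrying an amine or a carboxylic acid, or a longer chain, might answer that.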